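Swapping the hydroxynaphthyl group of compound 2 for hydroxyphenyl

The compounds below may be only part of what the source reports. "The series", "measured", "known", "first", "only" and "open" are said of these compounds alone.

Compound 2 `CN(C)CCn1cnnc1-c1cc(Oc2ccc(NC(=O)N/N=C/c3c(O)ccc4ccccc34)cc2F)ccn1` shares its core with compound 1 `COc1cc(/C=N/NC(=O)Nc2ccc(Oc3ccnc(-c4nncn4CCN(C)C)c3)c(F)c2)cc(OC)c1OC`; the two differ only in the aryl group on the carbon with a double bond to nitrogen. In a functional assay on MKN-45 cells (Homo sapiens) for cytotoxicity, read by MTT assay, with a stated time of 72 h (on this read-out higher numbers stand for weaker inhibition and lower numbers for stronger inhibition), compound 1 gives 2900 nM. In this assay compound 2 gives 2020 nM. The step of a 1.4-fold lower number from compound 1 to compound 2 (0.16 log units; within the scatter) is the only one measured so far, and it lies within the scatter, so on the numbers shown compound 2 stands alongside compound 1 rather than apart from it.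

Compound 3 `CN(C)CCn1cnnc1-c1cc(Oc2ccc(NC(=O)N/N=C/c3ccc(O)cc3)cc2F)ccn1` carries the change (4-hydroxyphenyl in place of 2-hydroxynaphthalen-1-yl on a carbon with a double bond to nitrogen). For the measured compounds named here, no measured step involves the 4-hydroxyphenyl group. Going by the values given here, the single measured step, a 1.4-fold lower number from compound 1 to compound 2 (0.16 log units; within the scatter), shows that exchanging one aryl group for another on this carbon produced a shift that stayed within the scatter. The step of a 1.5-fold higher number from compound 2 to compound 3 (0.17 log units; within the scatter) is therefore expected to stay within the scatter as well, with no clear direction. On that basis compound 3 is estimated at 3000 nM, with a range from 1200 nM to 8000 nM.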

Compound 3, half-maximal inhibitory concentration: 820 nM
Estimate against measurement, compound 3: 3.7-fold (0.56 log units) above; measured number below the stated range.
By their numbers in this assay, from the lowest: compound 3; then compounds 2 and 1 (each within the scatter of the next).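

At this position, on a carbon with a double bond to nitrogen, the choice of aryl group can move the number beyond the scatter in this assay: 4-hydroxyphenyl gives a lower number than 2-hydroxynaphthalen-1-yl (a 2.5-fold lower number from compound 2 to compound 3 (0.39 log units; beyond the scatter)) and than 3,4,5-trimethoxyphenyl (a 3.5-fold lower number from compound 1 to compound 3 (0.55 log units; beyond the scatter)), which leaves compound 3 with the lowest number of the three. A hydroxy group alone does not separate the compounds, as compound 2 also carries one and still stands within the scatter of compound 1 (a 1.4-fold lower number from compound 1 to compound 2 (0.16 log units; within the scatter)), so the single ring bearing a hydroxy group is what stands apart here, in this one example. Nothing measured here accounts for the lower number of compound 3.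

Whether a plain phenyl, a 4-methoxyphenyl or a 4-aminophenyl on this carbon would keep the lower number stays open, so the compounds shown do not tell the part of the single ring from that of its hydroxy group. From the compounds shown here alone, all three compounds also share one core, and whether this step would hold with a change elsewhere on that core is likewise open.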